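Working notes: fluoro to acetamido, compound 3 to compound 4

A few compounds are considered here, and "the series" means these few. Any claim that something is new, unique, unknown or untested is made for them only; others in the source may bear on it.

Measured so far in a functional assay on SMMC-7721 cells (Homo sapiens) for cytotoxicity, read by MTT assay, with a stated time of 24 h; a higher number here means a weaker inhibitor, a lower number a stronger inhibitor:
compound 1 `CC(=O)Nc1ccc(S(=O)(=O)N2C/C(=C\c3cccnc3)C(=O)/C(=C/c3ccccc3F)C2)cc1`: 10900 nM
compound 2 `Cc1ccc(S(=O)(=O)N2C/C(=C\c3cccnc3)C(=O)/C(=C/c3ccccc3C(F)(F)F)C2)cc1`: 6700 nM
compound 3 `O=C1/C(=C/c2cccnc2)CN(S(=O)(=O)c2ccc(F)cc2)C/C1=C\c1ccccc1C(F)(F)F`: 6390 nM

The three values form a single group. Compound 3 gives 6390 nM, which lies within the scatter of both other compounds, so it holds no separate place among them. The next compound to be read in this assay is compound 4 `CC(=O)Nc1ccc(S(=O)(=O)N2C/C(=C\c3cccnc3)C(=O)/C(=C/c3ccccc3C(F)(F)F)C2)cc1`. The change is acetamido in place of fluoro on an aromatic carbon. In words, this is acetamido in place of fluoro on an aromatic carbon, para to a large group, or 4-fluorophenyl to 4-acetamidophenyl.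

Among the measured compounds shown here, only one measured single-place step is available: a 1.0-fold lower number from compound 2 to compound 3 (0.02 log units; within the scatter), with fluoro in place of methyl on an aromatic carbon. That step stayed within the scatter, but it does not test an acetamido group. The nearest evidence for that group is compound 1, which carries acetamido and gives 10900 nM, also within the scatter of compound 3. With so few data, no step beyond the scatter is expected, and a slightly higher number is the only lean. The estimated step is a 1.2-fold higher number from compound 3 to compound 4 (0.07 log units; within the scatter). For compound 4 the expected value is 7500 nM, with an estimated range of 4000 nM to 14000 nM.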

Compound 4, half-maximal inhibitory concentration: 9830 nM
Estimate against measurement, compound 4: 1.3-fold (0.12 log units) below; the measured number falls inside the stated range.
By their numbers in this assay, from the lowest: compounds 3, 2, 4 and 1 (each within the scatter of the next).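

Notes on the acetamido change, read in this assay: on an aromatic carbon, para to a large group, acetamido brings a hydrogen-bond donor and a hydrogen-bond acceptor that neither fluoro nor methyl counts, yet the number stays within the scatter whether it replaces fluoro (a 1.5-fold higher number from compound 3 to compound 4 (0.19 log units; within the scatter)) or methyl (a 1.5-fold higher number from compound 2 to compound 4 (0.17 log units; within the scatter)). This position has now taken three groups, 4-fluorophenyl, the methyl-bearing ring and 4-acetamidophenyl, with trifluoromethyl held fixed on the other aromatic ring, and no separation has appeared among them. With acetamido held fixed instead, trifluoromethyl in place of fluoro also stays within the scatter (a 1.1-fold lower number from compound 1 to compound 4 (0.04 log units; within the scatter)), so neither single change shown here separates the compounds, and nothing at hand bears on why these numbers stay together.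

Still open is whether any group at this place can move the number beyond the scatter, since an amine, a carboxylic acid or a longer chain in place of acetamido would test a different kind of substituent from those shown. Also open, as far as these compounds go, is whether the same flat reading would hold with a chlorine or a methoxy group in place of trifluoromethyl on the other aromatic ring.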